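Varying the Alkyl Groups on a Purine-Type Core

The compounds below may be only part of what the source reports. "The series", "measured", "known", "first", "only" and "open" are said of these compounds alone.

Measured so far:
compound 1 `CCCn1cnc2c(N(C)C)ncnc21`, 14 mg/kg
compound 2 `CC(C)Cn1cnc2c(N(C)C)ncnc21`, 5 mg/kg
compound 3 `CN(c1ncnc2c1ncn2CC1CC1)C1CC1`, 7.5 mg/kg

In a functional assay on the whole organism for antagonist activity, with Rattus norvegicus as the target (on this read-out higher numbers stand for an effect only at larger amounts of compound and lower numbers for an effect already at smaller amounts), the three measured compounds sit close together. Compound 1 gives 14 mg/kg, and compound 2 gives 5 mg/kg; the two differ by methyl in place of hydrogen on a saturated chain carbon bound to two saturated chain carbons, and this step is a 2.8-fold lower number from compound 1 to compound 2 (0.45 log units; beyond the scatter). Compound 3 gives 7.5 mg/kg, a value that lies within the usual scatter of both compound 1 and compound 2, so no order can be read from it. The difference between the core of compound 3 and the core of compound 1 is not broken down here.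

Compound 4 `CCN(c1ncnc2c1ncn2CC1CC1)C1CC1` has not been measured in this assay. It differs from compound 3 by methyl in place of hydrogen on a saturated chain carbon bound to a nitrogen on an aromatic ring. Among the measured compounds shown here, this is the same kind of change as the one from compound 1 to compound 2, but at a different place: there the methyl entered on a saturated chain carbon bound to two saturated chain carbons, here on a saturated chain carbon bound to a nitrogen on an aromatic ring. Because the earlier step was a 2.8-fold lower number from compound 1 to compound 2 (0.45 log units; beyond the scatter), a step of similar or smaller size is expected here, so that compound 4 is estimated at 6 mg/kg, between 3 mg/kg and 12 mg/kg, which is expected to be a 1.3-fold lower number from compound 3 to compound 4 (0.10 log units; within the scatter).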

Compound 4, dose for half-maximal effect: 20 mg/kg
Beside the measured number, compound 4's estimate is 3.3-fold (0.52 log units) below it; the measured number lies above the stated range.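

In this assay, putting a methyl in place of a hydrogen on a saturated chain carbon bound to a nitrogen on an aromatic ring gives a 2.7-fold higher number from compound 3 to compound 4 (0.43 log units; beyond the scatter) and so moves the number up, whereas the earlier methyl step moved it down. Set side by side, the two steps point in opposite directions, and the gap between them is larger than scatter alone would account for: the same change on two cores in this assay, a 2.8-fold lower number (0.45 log units; beyond the scatter) from compound 1 to compound 2 and a 2.7-fold higher number (0.43 log units; beyond the scatter) from compound 3 to compound 4, 7.5-fold (0.87 log units) apart, beyond the scatter of two such steps

Among the compounds shown here, this shows that the effect of adding a methyl cannot simply be carried from one compound to another, but it does not show what sets the direction, as the two steps differ in both their core and the place of the methyl, and only one pair stands for each.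

A methyl step made at the same place on both cores would separate these two differences. Going by these compounds, it also remains open how the number would respond to a longer chain, such as cyclopropyl(butyl)amino in place of cyclopropyl(ethyl)amino.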